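The source may hold more compounds than are shown below. What is called first, only, known or untested is meant among the compounds shown, and "the series" means these compounds.

Measured so far in a functional assay on the whole organism (strain albino) for inhibition, with Rattus norvegicus as the target, read by paw edema, with stated times of 30 min and 2 h, at a dose of 100 mg/kg by the oral route; on this read-out higher numbers stand for more inhibition at the one dose given (going by the name of the read-out) and lower numbers for less inhibition:
compound 1 `COc1ccc(C2=NNC(c3c(Cl)cccc3Cl)C2)cc1OC`, giving 49%
compound 2 `COc1ccc(C2=NNC(c3c(Cl)cccc3Cl)C2)cc1`, giving 58%
compound 3 `COc1ccc(C2=NN(C(=O)CO[N+](=O)[O-])C(c3ccco3)C2)cc1OC`, giving 37%

Compound 1 stands second of the three numbers. Its nearest neighbour is compound 2, reached by a number 9 percentage points higher from compound 1 to compound 2 (within the scatter), the change being hydrogen in place of methoxy on an aromatic carbon. Among the measured compounds shown here, compound 3 gives the lowest of the three numbers, and the gap between compound 1 and compound 3 lies beyond the scatter; no single-point step joins these two.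

Compound 4 `COc1ccc(C2=NN(C(=O)C(C)O[N+](=O)[O-])C(c3c(Cl)cccc3Cl)C2)cc1OC` differs from compound 1 by a group of 8 heavy atoms (3 carbon, 1 nitrogen, 4 oxygen; no ring) in place of a hydrogen atom, on an amine nitrogen in a ring. For the measured compounds named here, no measured step matches this change. Going by the values given here, the only step known, from compound 1 to compound 2, concerns an aromatic substituent and lies within the scatter, so it says nothing about a substituent on the amine nitrogen in a ring. Compound 3, which likewise carries a group in place of the hydrogen on that nitrogen, gives a number lower than compound 1, but it differs from compound 1 in further places as well, so it points only loosely. A modest downward step is therefore expected, a number 7 percentage points lower from compound 1 to compound 4 (within the scatter), around the edge of the scatter. Compound 4 is estimated at 42%, with a range from 30% to 55%.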

Compound 4, a percentage reported as inhibition, in the whole organism at one dose (the size of the read-out at that dose, not a potency): 53%
Beside the measured number, compound 4's estimate is 11 percentage points below it, within the range that was stated.
By their numbers in this assay, from the lowest: compound 3; then compounds 1, 4 and 2 (each within the scatter of the next).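

In this assay, among the compounds shown here, the amine nitrogen in a ring of the core of compound 1 takes a group of 8 heavy atoms (3 carbon, 1 nitrogen, 4 oxygen; no ring) in place of its hydrogen, with a number 4 percentage points higher from compound 1 to compound 4 (within the scatter), the first single-place reading at this position. On this background, then, the hydrogen on that nitrogen is not needed to keep the read-out at the one dose within the scatter, even with a group of this size in its place. Nothing measured on hand speaks to the reason for this result.

From the compounds shown here alone, whether a plain acetyl group, a carboxylic acid or a longer chain on the same nitrogen would read the same stays open. Also open, going by these compounds, is whether the group's effect holds with hydrogen in place of methoxy on the aromatic carbon, or with a different group on the neighbouring ring atom in place of the 2,6-dichlorophenyl group.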